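Ethoxycarbonyl in Place of Methyl on a Sulfur Chain

A few compounds are considered here, and "the series" means these few. Any claim that something is new, unique, unknown or untested is made for them only; others in the source may bear on it.

Compound 1 `CCSc1nnc(-c2cc(OC)c(OC)c(OC)c2)n1-c1ccc(OC)cc1` gives in a functional assay on HT-29 cells (Homo sapiens) for inhibition, read by MTT assay, with a stated time of 48 h (a lower number here means a stronger inhibitor, a higher number a weaker inhibitor), the value > 60000 nM, which is a limit of the assay and not a number.
Compound 2 `COc1ccc(-n2c(SCC(=O)c3ccc(F)cc3)nnc2-c2cc(OC)c(OC)c(OC)c2)cc1` gives in this assay the value 42500 nM.
Compound 3 `CCSc1nnc(-c2cc(OC)c(OC)c(OC)c2)n1-c1ccc(N(C)C)cc1` gives in this assay the value > 60000 nM, again a limit of the assay.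

Compound 3 therefore stands at the limit of this assay rather than at a measured number, and it sits at the limit of > 60000 nM in this assay, at which 2 of the 3 values shown sit. The change from compound 1 to compound 3, dimethylamino in place of methoxy on an aromatic carbon, gives a step that the two limits leave unreadable from compound 1 to compound 3.

Compound 4 `CCOC(=O)CSc1nnc(-c2cc(OC)c(OC)c(OC)c2)n1-c1ccc(N(C)C)cc1` differs from compound 3 by ethoxycarbonyl in place of methyl on a saturated chain carbon bound to a sulfur. Within the data shown here, the one measured step at the same place, on a saturated chain carbon bound to a sulfur, is an at least 1.4-fold lower number from compound 1 to compound 2 (0.14 log units; that floor lies within the scatter), and its floor lies within the scatter. On that evidence no step beyond the scatter is expected in this assay, and compound 4 is expected to remain near the limit. The estimate for compound 4 is 50000 nM, with a range from 20000 nM to 120000 nM. That estimate means a step of an at least 1.2-fold lower number from compound 3 to compound 4 (0.07 log units; that floor lies within the scatter), expected to stay within the scatter.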

Compound 4, half-maximal inhibitory concentration: 28800 nM
Compound 4: the middle estimate sits 1.7-fold (0.24 log units) above what was measured; measured number inside the range.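

On the dimethylamino compound, ethoxycarbonyl in place of methyl on a saturated chain carbon bound to a sulfur gives in this assay an at least 2.0-fold lower number from compound 3 to compound 4 (0.31 log units; beyond the scatter). Among these compounds, the one earlier step at this place had a floor within the scatter, so the sulfur chain now appears as a place where a single change can give a step beyond it. The full size of this step cannot be read, because compound 3 stands at a limit and not at a number: the limit of > 60000 nM in this assay, at which 2 of the 4 values shown sit.

The compounds shown leave open whether ethoxycarbonyl gives a similar step when methoxy takes the place of dimethylamino on the aromatic carbon. They also leave open how a carboxylic acid, an amide or a longer chain would read at the same place on the sulfur chain.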